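Biphenyl-to-chloro swap on an oxazolidinone EP4 ligand

The compounds below may be only part of what the source reports. "The series", "measured", "known", "first", "only" and "open" are said of these compounds alone.

Three compounds carry numbers in an assay on CHO cells for displacement of a labelled ligand from prostaglandin E2 receptor EP4 subtype (Mus musculus), read by scintillation counting, with a stated time of 60 min; on this read-out lower numbers stand for stronger inhibition and higher numbers for weaker inhibition. Compound 1 `CCCc1cccc(C[C@H](O)/C=C/[C@H]2CCC(=S)N2CCCCCCC(=O)O)c1` gives 0.4 nM and compound 3 `Cc1cccc(C[C@H](O)/C=C/[C@H]2CCC(=S)N2CCSCCCC(=O)O)c1` gives 0.5 nM. Compound 2 `O=C(O)CCCSCCN1C(=O)OC[C@@H]1/C=C/[C@@H](O)Cc1cccc(-c2ccccc2)c1` gives 28 nM, the highest of the three, well beyond the scatter from both others. Compound 1 and compound 3 differ from compound 2 at more than one place, so that gap cannot be assigned to any single change. Compound 4 `O=C(O)CCCSCCN1C(=O)OC[C@@H]1/C=C/[C@@H](O)Cc1cccc(Cl)c1` keeps the core of compound 2 and differs only by chloro in place of phenyl on an aromatic carbon. With no single-point comparison on record, a moderate step toward lower numbers is expected, a 2.8-fold lower number from compound 2 to compound 4 (0.45 log units; beyond the scatter), not a large one. Compound 4 is estimated at 10 nM, with a range from 3 nM to 40 nM.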

Compound 4, inhibition constant: 1.5 nM
Compound 4: middle estimate off by 6.7-fold (0.82 log units), on the high side; measured number outside the range, below it.
By their numbers in this assay, from the lowest: compounds 1 and 3 (each within the scatter of the next); then compound 4; then compound 2.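

In this assay, within the data shown here, the step for chloro in place of phenyl on an aromatic carbon, meta to a large group, is a 19-fold lower number from compound 2 to compound 4 (1.27 log units; beyond the scatter) and is the only single-place comparison. This position therefore does not require the phenyl ring for a low number on this core. Nothing on record gives a cause for the step. On these data alone, whether a methyl, a methoxy or an amine at this position would track chloro or phenyl remains open, as does whether the same swap would carry over to the core of compound 1 or compound 3.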